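Amide cap change in a cinnamate ester series

The compounds below may be only part of what the source reports. "The series", "measured", "known", "first", "only" and "open" are said of these compounds alone.

Among the compounds with values here, compound 1 `COCOc1cc(/C=C/C(=O)OCC(=O)NCc2ccco2)ccc1OCc1ccccc1` is the only member of this group with a numerical read-out: in a functional assay on HL-60 cells (Homo sapiens) for cytotoxicity, read by MTT assay, with a stated time of 72 h (a higher number here means a weaker inhibitor, a lower number a stronger inhibitor), compound 1 gives 82200 nM. Compound 2 `CCOc1ccc(COc2c(OC)cc(/C=C/C(=O)N3CCN(Cc4ccc(Cl)c(Cl)c4)CC3)cc2OC)cc1` is the other member. In this assay compound 2 gives only a limit, > 200000 nM, and no number. Compound 1 therefore stands as the single measured point, with one value in the set sitting at the limit of > 200000 nM in this assay, at which 1 of the 2 values shown sits. Within the data shown here, no pair of measured compounds differs in a single place, so no measured step is available to weigh any one change.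

Compound 3 `COCOc1cc(/C=C/C(=O)OCC(=O)Nc2ccc(OC)cc2)ccc1OCc1ccccc1` is the next candidate. Its change from compound 1 is 4-methoxyphenyl in place of (furan-2-yl)methyl on an amide-type nitrogen. The remainder of the core of compound 1 is kept. Among the measured compounds shown here, with no measured step to lean on, the expectation rests on compound 1 alone. The step is expected to be a 1.1-fold lower number from compound 1 to compound 3 (0.04 log units; within the scatter), not beyond the scatter in either direction. Compound 3 is estimated at 75000 nM in this assay, with a range from 25000 nM to 200000 nM. Compound 3 may also return only a limit in this assay.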

Compound 3, half-maximal inhibitory concentration: > 200000 nM
Compound 3: only a limit was reported (the forecaster's own chance of this, stated with the estimate: 30%); middle value at least 2.6-fold (0.42 log units) away from the limit.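

Within the data shown here, replacing (furan-2-yl)methyl with 4-methoxyphenyl on the amide-type nitrogen gives an at least 2.4-fold higher number from compound 1 to compound 3 (0.38 log units; beyond the scatter) in this assay, the first measured step and the first sign that the read-out responds to a change at this position. Compound 3 returns only a limit, > 200000 nM, so this step has a floor and no upper bound. The core of compound 1 does not by itself secure a numerical read-out, and limits now make up most of the set: the limit of > 200000 nM in this assay, at which 2 of the 3 values shown sit.

The change alters the ring, its substituent and the methylene link together, so a benzyl or plain phenyl group on the amide-type nitrogen would be needed to separate these contributions. Going by these compounds, it also remains open whether any group at this position can give a lower number than compound 1, at 82200 nM, with (pyridin-2-yl)methyl and the longer 2-(furan-2-yl)ethyl chain as candidates.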